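This account rests on a few compounds, and the source may have more. Where it says the series, first, only, none or still open, it means among the compounds named here.

Measured in a functional assay on HEp-2 cells (Homo sapiens) for inhibition; a higher number here means that more compound is needed for the effect, a lower number that less compound is needed:

- compound 1 `CSc1ncnc2[nH]nnc12`: > 300 uM (a limit of the assay)
- compound 2 `CSc1ncnc2c1nnn2[C@@H]1O[C@H](CO)[C@@H](O)[C@H]1O`: 0.02 uM

Within the data shown here, compound 2 stands at 0.02 uM, the only actual number so far. Compound 3 `CCSc1ncnc2c1nnn2[C@@H]1O[C@H](CO)[C@@H](O)[C@H]1O` has methyl in place of hydrogen on a saturated chain carbon bound to a sulfur, so methylsulfanyl becomes ethylsulfanyl (methyl in place of hydrogen on a saturated chain carbon bound to a sulfur). Among the measured compounds shown here, no measured step gives the size of such a change, so the expectation is a rough one: a moderate loss, meaning a higher number in this assay. The expected change is a 15-fold higher number from compound 2 to compound 3 (1.18 log units; beyond the scatter). Compound 3 is estimated at 0.3 uM, with an expected range of 0.03 uM to 5 uM.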

Compound 3, concentration for half-maximal effect: 0.1 uM
Estimate against measurement, compound 3: 3.0-fold (0.48 log units) above; low and high end bracket the measured number.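

In this assay the step from methylsulfanyl to ethylsulfanyl gives a 5.0-fold higher number from compound 2 to compound 3 (0.70 log units; beyond the scatter), the first measured size for a change at this position. One added methyl on the saturated chain carbon bound to a sulfur therefore costs potency without abolishing it, and compound 3 still reads 0.1 uM. Nothing measured here accounts for the size of this step.

As far as these compounds go, whether a longer chain such as propylsulfanyl extends the loss remains open, since one step sets no trend. Also open, from the compounds shown here alone, is how an amine at this position of the shared core would compare.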